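Sulfonyl aryl change on the core of compound 1

The source may report more compounds than this note shows. Statements on the series, on what has been measured and on what is new or still open speak of the compounds shown alone.

Among the measured compounds shown here, in a functional assay on A2780 cells (Homo sapiens) for inhibition, read by sulforhodamine B assay, with a stated time of 72 h (a higher number here means a weaker inhibitor, a lower number a stronger inhibitor), compound 1 `Cc1ccccc1S(=O)(=O)c1ccc(CNC(=O)c2cc3cnccc3[nH]2)cc1` gives 13 nM, the only actual number in the set. Compound 2 `O=C(NCc1ccc(S(=O)(=O)c2ccccc2)cc1)c1cc2ncccc2s1` reads > 10000 nM, which is a limit of the assay. Compound 3 `O=C(NCc1ccc(S(=O)(=O)c2ccccc2)cc1)c1nc2ccncc2s1` reads > 10000 nM, also a limit. The set thus carries (the limit of > 10000 nM in this assay, at which 2 of the 3 values shown sit).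

Compound 4 `O=C(NCc1ccc(S(=O)(=O)c2cccc(F)c2)cc1)c1cc2cnccc2[nH]1` keeps the core of compound 1 and alters only the aryl group: 3-fluorophenyl in place of 2-methylphenyl on a sulfonyl sulfur. In words, 3-fluorophenyl stands in place of 2-methylphenyl on a sulfonyl sulfur.

For the measured compounds named here, the one measured step is a step that the two limits leave unreadable from compound 2 to compound 3. Going by the values given here, that change lies on a carbonyl carbon, not on the sulfonyl sulfur, and it gives no size, so no measured step bears directly on this change. With the core kept, no shift beyond the scatter is expected in this assay, on thin support. The estimated change is a 1.1-fold lower number from compound 1 to compound 4 (0.03 log units; within the scatter). Compound 4 is expected at 12 nM, with an estimated range from 3 nM to 50 nM.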

Compound 4, half-maximal inhibitory concentration: 11 nM
Compound 4: the middle estimate sits 1.1-fold (0.04 log units) above what was measured, within the range that was stated.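

In this assay, the change at the sulfonyl sulfur gives a readable size, a 1.2-fold lower number from compound 1 to compound 4 (0.07 log units; within the scatter), so with the core of compound 1 kept, 3-fluorophenyl can stand in place of 2-methylphenyl without a shift beyond the scatter. The earlier step, on a carbonyl carbon, cannot be read, which makes this the first size available in the series and the first for this place. Nothing shown bears on the cause of this outcome.

Going by these compounds, with only these two aryl groups on the shared core, the reach of this result at the sulfonyl sulfur remains open. It is not shown whether a phenyl carrying an amine or a carboxylic acid, or a longer chain in place of the aryl group, would hold the number in the same way.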